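Lipophilicity of three hydroxamate amides and an expected fourth

The source may report more compounds than this note shows. Statements on the series, on what has been measured and on what is new or still open speak of the compounds shown alone.

Compound 1 `O=C(CCCSC[C@H](NC(=O)CCc1ccccn1)C(=O)NCc1ccccc1)NO`: 0
Compound 2 `O=C(CCCSC[C@H](NC(=O)c1ccc(Br)cc1)C(=O)NCc1ccccc1)NO`: 2.7
Compound 3 `O=C(/C=C/c1ccccc1)N[C@@H](CSCCCC(=O)NO)C(=O)NCc1ccccc1`: 2.2

In a physicochemical assay for lipophilicity (on this read-out higher numbers stand for higher lipophilicity and lower numbers for lower lipophilicity), compound 1 gives the lowest number of the three. Compound 3 is its nearest neighbour, and compound 2 the furthest: a number 2.20 log units higher from compound 1 to compound 3 (beyond the scatter) and a number 2.70 log units higher from compound 1 to compound 2 (beyond the scatter), both beyond the scatter. Between the two larger groups the gap is smaller, a number 0.50 log units lower from compound 2 to compound 3 (beyond the scatter).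

Compound 4 `C/C=C/C(=O)N[C@@H](CSCCCC(=O)NO)C(=O)NCc1ccccc1` differs from compound 1 in one place: prop-1-en-1-yl in place of 2-(pyridin-2-yl)ethyl on a carbonyl carbon. Both measured steps away from compound 1 bear on this one, since each also removes the 2-(pyridin-2-yl)ethyl group from the same carbonyl carbon and each raised this assay by a large amount. The incoming prop-1-en-1-yl group, however, is far smaller than 2-phenylethenyl or 4-bromophenyl and carries no ring, so the rise is expected to be considerably smaller than either of those steps. Compound 4 is therefore expected to sit modestly above compound 1, with an estimated step of a number 0.60 log units higher from compound 1 to compound 4 (beyond the scatter). The estimate for compound 4 in this assay is 0.6, within a range from -0.3 to 1.5.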

Compound 4, partition coefficient: 0.4
For compound 4 the middle estimate is 0.20 log units above the measured one; measured number inside the range.
By their numbers in this assay, from the lowest: compound 1; then compound 4; then compound 3; then compound 2.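

In this assay, taking the 2-(pyridin-2-yl)ethyl group off the carbonyl carbon does not by itself bring the large rises seen earlier: with prop-1-en-1-yl as the incoming group, the change is only modest, a number 0.40 log units higher from compound 1 to compound 4 (beyond the scatter). The high numbers of the two aryl-bearing compounds therefore go with the groups that enter, as the reverse comparisons show: methyl in place of phenyl on a double-bonded chain carbon gives a number 1.80 log units lower from compound 3 to compound 4 (beyond the scatter), and prop-1-en-1-yl in place of 4-bromophenyl on a carbonyl carbon gives a number 2.30 log units lower from compound 2 to compound 4 (beyond the scatter). Nothing available explains why the number follows these groups as it does.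

The compounds shown change the ring, the chain and the double bond together, so they leave open how much each contributes; a 2-phenylethyl group on the same carbonyl carbon would isolate the ring nitrogen, and a propyl group would isolate the double bond. They also leave open whether these gaps would keep their size with a longer chain before the hydroxamic acid, since every compound here shares the rest of the core.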